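This account rests on a few compounds, and the source may have more. Where it says the series, first, only, none or still open, it means among the compounds named here.

Measured in a functional assay on HepG2 cells (Homo sapiens) for cytotoxicity, read by MTT assay; on this read-out lower numbers stand for stronger inhibition and higher numbers for weaker inhibition:
Compound 1 `C#CCOc1cc(/C=C/C(=O)c2ccc(OC)c3c2OC(C)(C)C=C3)ccc1OC`: > 10000 nM, a limit of the assay
Compound 2 `COc1ccc(/C=C/C(=O)c2ccc(OC)c3c2OC(C)(C)C=C3)cc1OCCCN(C)C`: 5550 nM
Compound 3 `COc1ccc(/C=C/C(=O)c2ccc(OC)c3c2OC(C)(C)C=C3)cc1OC(=O)CCl`: 120 nM

Of the two true numbers in this assay, the lower belongs to compound 3, at 120 nM. Compound 2 is the nearest, at 5550 nM.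

Compound 4 `COc1ccc(/C=C/C(=O)c2ccc(OC)c3c2OC(C)(C)C=C3)cc1CS(C)(=O)=O` differs from compound 3 at a single place: (methylsulfonyl)methyl in place of ((chloromethyl)carbonyl)oxy on an aromatic carbon. It therefore no longer carries the (chloromethyl)carbonyl group. For the measured compounds named here, two measured steps bear on this change: an at least 83-fold lower number from compound 1 to compound 3 (1.92 log units; beyond the scatter), and a 46-fold lower number from compound 2 to compound 3 (1.67 log units; beyond the scatter). Both are large, and both end at that group. Neither compares the incoming (methylsulfonyl)methyl directly, so the expectation rests on the loss alone. Compound 4 is expected to lie nearer compound 2 at 5550 nM than compound 3, with a large move to a higher number in this assay. The expected change is a 42-fold higher number from compound 3 to compound 4 (1.62 log units; beyond the scatter). For compound 4 the estimated value is 5000 nM, with an expected range of 1000 nM to 20000 nM.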

Compound 4, half-maximal inhibitory concentration: 9180 nM
Estimate against measurement, compound 4: 1.8-fold (0.26 log units) below, within the range that was stated.
By their numbers in this assay, from the lowest: compound 3; then compounds 2 and 4 (each within the scatter of the next). At a limit, above all of these: compound 1.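

In this assay the exchange of ((chloromethyl)carbonyl)oxy for (methylsulfonyl)methyl is a large step, giving a 77-fold higher number from compound 3 to compound 4 (1.88 log units; beyond the scatter) and so not preserving the low number of compound 3, although the two groups match in heavy-atom and hydrogen-bond acceptor counts. With a 1.7-fold higher number from compound 2 to compound 4 (0.22 log units; within the scatter) compound 2 and compound 4 cannot be told apart, so among the readable values, only compound 3, with its ((chloromethyl)carbonyl)oxy group, stands clearly apart at this position. The figure an at least 1.0-fold lower number from compound 1 to compound 4 (0.03 log units; that floor lies within the scatter) is only a floor and cannot be read further, because one of its two values is a limit: the limit of > 10000 nM in this assay, at which 1 of the 4 values shown sits.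

The compounds shown leave open whether the low number of compound 3 goes with the chlorine or with the ester. An acetoxy group or a chloroacetamide on the same aromatic carbon would separate these two possibilities.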